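The source may hold more compounds than are shown below. What is called first, only, known or untested is meant among the compounds shown, and "the series" means these compounds.

Compounds measured in an assay on tissue (PBMC cells) for agonist activity at Toll-like receptor 8 (Homo sapiens), with a stated time of 24 h; on this read-out higher numbers stand for an effect only at larger amounts of compound and lower numbers for an effect already at smaller amounts:
compound 1, `CCCCNc1nc(N)nc2cccnc12`, 1900 nM
compound 2, `CCC[C@H](CO)Nc1nc(N)nc2cccnc12`, 19000 nM
compound 3, `CCC[C@@H](CO)Nc1nc(N)nc2cccnc12`, 430 nM

Compound 3 gives the lowest of the three numbers in this assay; compound 1 lies nearest to it, compound 2 furthest. The measured steps are a 4.4-fold lower number from compound 1 to compound 3 (0.65 log units; beyond the scatter), a 10-fold higher number from compound 1 to compound 2 (1.00 log units; beyond the scatter) and a 44-fold lower number from compound 2 to compound 3 (1.65 log units; beyond the scatter), the last of which rests on (the fact that compounds 2 and 3 differ only in the configuration as drawn). Compound 4, `CCCC[C@@H](CO)Nc1nc(N)nc2cccnc12`, differs from compound 3 by methyl in place of hydrogen on a saturated chain carbon, four bonds along the chain from a nitrogen on an aromatic ring. No measured step changes the length of this chain, so the outcome of lengthening it cannot be read from the shown steps, and a step in this assay within the scatter of compound 3 is the plainest expectation. Compound 4 is therefore estimated at 300 nM, with a range from 100 nM to 1000 nM, which would mean a 1.4-fold lower number from compound 3 to compound 4 (0.16 log units; within the scatter).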

Compound 4, half-maximal effective concentration: 420 nM
Compound 4: the middle estimate sits 1.4-fold (0.15 log units) below what was measured; low and high end bracket the measured number.
By their numbers in this assay, from the lowest: compounds 4 and 3 (each within the scatter of the next); then compound 1; then compound 2.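

In this assay, going from propyl to butyl by methyl in place of hydrogen gives a 1.0-fold lower number from compound 3 to compound 4 (0.01 log units; within the scatter). This position, four bonds along the chain from a nitrogen on an aromatic ring, had not been changed by any earlier step, and with the hydroxymethyl kept it takes the added methyl without a step beyond the scatter. Nothing in the evidence at hand bears on why this step is so small.

As far as these compounds go, it remains open whether a longer chain, such as pentyl or hexyl, would keep this number. The same applies to an amine or a carboxylic acid at the chain end.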